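Working notes: chloro on the anilino ring, compound 3 to 4

The compounds below may be only part of what the source reports. "The series", "measured", "known", "first", "only" and "open" are said of these compounds alone.

Measured so far in an assay on HEK293 cells for inhibition of protein deacetylase HDAC6 (Homo sapiens); a higher number here means a weaker inhibitor, a lower number a stronger inhibitor:
compound 1, `CCSC(=S)SCC(=O)c1cccc(NC(C)=O)c1` — 329 nM
compound 2, `CCSC(=S)SCC(=O)c1ccc(C(=O)NCCOc2ccccc2)cc1` — 483 nM
compound 3, `CCSC(=S)SCC(=O)c1ccc(C(=O)Nc2ccccc2)cc1` — 521 nM

Compound 3 carries the highest of the three numbers, yet its gaps to compound 2 and to compound 1 both lie within the scatter, so the three compounds stand together rather than in an order. Compound 4, `CCSC(=S)SCC(=O)c1ccc(C(=O)Nc2ccc(Cl)cc2)cc1`, differs from compound 3 by chloro in place of hydrogen on an aromatic carbon.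

For the measured compounds named here, the only step measured, a 1.1-fold higher number from compound 2 to compound 3 (0.03 log units; within the scatter), exchanges the group on the amide-type nitrogen and stays within the scatter; no measured pair shows a chloro entering an aromatic carbon, so nothing bears directly on this change. The expectation is therefore a step of a 1.0-fold lower number from compound 3 to compound 4 (0.02 log units; within the scatter), no change beyond the scatter. For compound 4 the estimated value is 500 nM, with a range from 250 nM to 1000 nM.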

Compound 4, half-maximal inhibitory concentration: 1450 nM
Compound 4: middle estimate off by 2.9-fold (0.46 log units), on the low side; measured number above the stated range.
By their numbers in this assay, from the lowest: compounds 1, 2 and 3 (each within the scatter of the next); then compound 4.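

In this assay the anilino ring of compound 3 does not tolerate every change: chloro in place of hydrogen on an aromatic carbon gives a 2.8-fold higher number from compound 3 to compound 4 (0.44 log units; beyond the scatter) and so passes beyond the scatter. Replacing 2-phenoxyethyl on the amide-type nitrogen with 4-chlorophenyl gives a 3.0-fold higher number from compound 2 to compound 4 (0.48 log units; beyond the scatter) as well, whereas phenyl in that place gives only a 1.1-fold higher number from compound 2 to compound 3 (0.03 log units; within the scatter) and stays within the scatter. No measurement shown accounts for this rise.

From the compounds shown here alone, whether the rise is specific to chloro remains open. A methoxy, an amine or a carboxylic acid on the same aromatic carbon would test this.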